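Rearranging the amine side chain: little change expected

The source may report more compounds than this note shows. Statements on the series, on what has been measured and on what is new or still open speak of the compounds shown alone.

Compound 1 `CCCCCN(CCCCC)CCCOc1ccc(S(=O)(=O)c2c(C(C)C)cn3ccccc23)cc1` gives 89.6 nM
Compound 2 `CCCN(CCC)CCCOc1ccc(S(=O)(=O)c2c(CC)cn3ccccc23)cc1` gives 150 nM
Compound 3 `CCCCN(CCCC)CCCCCOc1ccc(S(=O)(=O)c2c(CC)cn3ccccc23)cc1` gives 97.4 nM

In a functional assay (aorta) with Rattus norvegicus as the target (a lower number here means a stronger inhibitor, a higher number a weaker inhibitor), compound 3 gives 97.4 nM and lies within the usual scatter of both other compounds, so these values cannot be ranked. The change to compound 4 `CCCCCN(CCCCC)CCCOc1ccc(S(=O)(=O)c2c(CC)cn3ccccc23)cc1` is dipentylamino in place of 2-(dibutylamino)ethyl on a saturated chain carbon, three bonds along the chain from an oxygen on an aromatic ring and the two have the same atoms, joined differently. Within the data shown here, one measured step bears on this place on the chain: a 1.5-fold lower number from compound 2 to compound 3 (0.19 log units; within the scatter) and it brought in the group that now leaves. That is a single small step, so no change beyond the scatter is expected in this assay here. The expected step is a 1.0-fold lower number from compound 3 to compound 4 (0.01 log units; within the scatter) and it carries no clear direction. The estimate for compound 4 is 95 nM with an expected range from 50 nM to 180 nM around it.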

Compound 4, half-maximal inhibitory concentration: 62.4 nM
For compound 4 the middle estimate is 1.5-fold (0.18 log units) above the measured one; measured number inside the range.
By their numbers in this assay, from the lowest: compounds 4, 1, 3 and 2 (each within the scatter of the next, the first and the last beyond it).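

In this assay the rearranged side chain gives a 1.6-fold lower number from compound 3 to compound 4 (0.19 log units; within the scatter) and so cannot be told apart from no change. Dipentylamino in place of dipropylamino gives a 2.4-fold lower number from compound 2 to compound 4 (0.38 log units; beyond the scatter) and is the first modest step beyond the scatter at this place on the chain. Hydrogen in place of methyl, on the saturated chain carbon bound to an aromatic carbon, gives a 1.4-fold lower number from compound 1 to compound 4 (0.16 log units; within the scatter) and also stays unresolved.

As far as these compounds go, how a longer dihexylamino group or a ring amine such as piperidine would behave here remains open. The reason for these numbers also stays open, with no supporting evidence available.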